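Benzyloxy series: a fluoro on the benzyl ring

A few compounds are considered here, and "the series" means these few. Any claim that something is new, unique, unknown or untested is made for them only; others in the source may bear on it.

Measured compounds:
compound 1 `CCCCCCOc1cc(C(C)(C)C)ccc1CNC(=O)C(C)c1ccc(NS(C)(=O)=O)c(F)c1`, 0.5 nM
compound 2 `CC(C)COc1cc(C(C)(C)C)ccc1CNC(=O)C(C)c1ccc(NS(C)(=O)=O)c(F)c1`, 2.1 nM
compound 3 `CC(C(=O)NCc1ccc(C(C)(C)C)cc1OCc1ccccc1)c1ccc(NS(C)(=O)=O)c(F)c1`, 2.9 nM

All three share a core and differ only in the group on the ether oxygen. In an assay on cells for antagonist activity at transient receptor potential cation channel subfamily V member 1 (Homo sapiens), read by FLIPR and calcium flux, with a stated time of 6 min (a lower number here means a stronger inhibitor, a higher number a weaker inhibitor), compound 3 gives the highest of the three numbers; one of the two steps that lead to it, a 1.4-fold higher number from compound 2 to compound 3 (0.14 log units; within the scatter), lies within the scatter, whereas the other, a 5.8-fold higher number from compound 1 to compound 3 (0.76 log units; beyond the scatter), lies beyond it. The steps of a 4.2-fold higher number from compound 1 to compound 2 (0.62 log units; beyond the scatter) and a 5.8-fold higher number from compound 1 to compound 3 (0.76 log units; beyond the scatter) concern the ether substituent itself, not a ring substituent.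

Compound 4 `CC(C(=O)NCc1ccc(C(C)(C)C)cc1OCc1ccc(F)cc1)c1ccc(NS(C)(=O)=O)c(F)c1` differs from compound 3 by fluoro in place of hydrogen on an aromatic carbon. For the measured compounds named here, none of the measured steps touches a substituent on the benzyl ring, so there is nothing to scale the step from. The expected step of no change at the digits printed from compound 3 to compound 4 (within the scatter) is therefore none beyond the scatter. Compound 4 is estimated at 2.9 nM in this assay, with a range of 1.1 nM to 7.5 nM.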

Compound 4, inhibition constant: 3.8 nM
Compound 4: the middle estimate sits 1.3-fold (0.12 log units) below what was measured; the range from low to high includes it.
By their numbers in this assay, from the lowest: compound 1; then compounds 2, 3 and 4 (each within the scatter of the next).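

In this assay, a fluoro on the benzyl ring, para to a large group, gives a step that cannot be told from the scatter (a 1.3-fold higher number from compound 3 to compound 4 (0.12 log units; within the scatter)), so this position accepts the change with no measurable effect on the number. The 4-fluorophenyl group also stays within the scatter of isopropyl (a 1.8-fold higher number from compound 2 to compound 4 (0.26 log units; within the scatter)), while the gap to pentyl remains beyond it (a 7.6-fold higher number from compound 1 to compound 4 (0.88 log units; beyond the scatter)), so this fluoro does not bring the benzyl series level with compound 1. Nothing available bears on the reason for this result.

A single small atom at one ring position leaves open whether chloro, methoxy or trifluoromethyl in the same place would move the number beyond the scatter. Also open, on these data alone, is how an amine or a carboxylic acid there would behave.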